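Toward a fluorinated aryl group on the shared core

A few compounds are considered here, and "the series" means these few. Any claim that something is new, unique, unknown or untested is made for them only; others in the source may bear on it.

Among the compounds with values here, the two compounds measured so far share one core and differ only in the group carried on the pendant aromatic ring. Compound 1 `CC(C)C[C@H](N)CN(C(=O)[C@@H]1C[C@H]1c1ccccc1)c1cccc(-c2ccccc2)c1` gives 23000 nM in a functional assay for agonist activity at G protein-coupled receptor 88 (Homo sapiens), read by HTRF and cAMP accumulation; on this read-out lower numbers stand for an effect already at smaller amounts and higher numbers for an effect only at larger amounts of compound. Compound 2 `CC(C)C[C@H](N)CN(C(=O)[C@@H]1C[C@H]1c1ccccc1)c1ccc(C2=CCCC2)cc1` gives 1200 nM in this assay, the lowest of the two numbers, with compound 1 standing a good way higher, beyond the scatter. Compound 3 `CC(C)C[C@H](N)CN(C(=O)[C@@H]1C[C@H]1c1ccccc1)c1ccc(-c2ccccc2F)cc1` has not yet been measured; relative to compound 2 it carries 2-fluorophenyl in place of cyclopent-1-en-1-yl on an aromatic carbon. Within the data shown here, no step between measured compounds tells how such an exchange plays out here, so the expectation rests on compound 2 alone, whose 1200 nM is the only anchor. The account expects the step of a 1.5-fold lower number from compound 2 to compound 3 (0.18 log units; within the scatter) to stay within the scatter, or at most to lower the number modestly. Compound 3 is therefore estimated at 800 nM, within a range from 200 nM to 4000 nM.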

Compound 3, half-maximal effective concentration: 1600 nM
The estimate for compound 3 lay 2.0-fold (0.30 log units) below the measured number; the range from low to high includes it.
By their numbers in this assay, from the lowest: compounds 2 and 3 (each within the scatter of the next); then compound 1.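

In this assay, putting 2-fluorophenyl in place of cyclopent-1-en-1-yl on this aromatic carbon, para to a large group, gives a 1.3-fold higher number from compound 2 to compound 3 (0.12 log units; within the scatter) and so leaves the two groups indistinguishable here. This first step at the position shows that a six-membered aromatic ring of carbon only, with 7 heavy atoms, can take the place of a five-membered non-aromatic ring with 5 heavy atoms while the number stays within the scatter. Nothing at hand bears on why the two groups read alike.

As far as these compounds go, it remains open what the fluorine itself contributes to the 2-fluorophenyl group. From the compounds shown here alone, it is also open whether a nitrile or a methoxy group in its place, or a cyclopentyl group on the same carbon, would move the number beyond the scatter.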